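Cyclopropyl for Propyl on Two Related Cores

A few compounds are considered here, and "the series" means these few. Any claim that something is new, unique, unknown or untested is made for them only; others in the source may bear on it.

Of the compounds shown here, three have been measured in a functional assay (aorta) with Oryctolagus cuniculus as the target; a lower number here means tighter binding, a higher number weaker binding. Compound 1 `CCCc1nc2cccnc2n1Cc1cc(Cl)c(O)c(Cl)c1` gives 31.6 nM. Compound 3 `Oc1c(Cl)cc(Cn2c(C3CC3)nc3cccnc32)cc1Cl`, which carries cyclopropyl in place of propyl on an aromatic carbon, gives 20 nM. The change between them, (cyclopropyl in place of propyl on an aromatic carbon), made a 1.6-fold lower number from compound 1 to compound 3 (0.20 log units; within the scatter). Compound 2 `CCCc1nc2ncccc2n1Cc1cc(Cl)c(O)c(Cl)c1` has the same atoms as compound 1 joined differently; the difference between the two cores is not broken down here. In this assay compound 2 gives 794 nM, the highest of the three numbers and beyond the scatter from both compound 1 and compound 3.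

Compound 4 `Oc1c(Cl)cc(Cn2c(C3CC3)nc3ncccc32)cc1Cl` has not yet been measured. It differs from compound 2 by cyclopropyl in place of propyl on an aromatic carbon, the same change as from compound 1 to compound 3, since the two places read alike word for word. Among the measured compounds shown here, for compound 4 the step expected is a 1.6-fold lower number from compound 2 to compound 4 (0.20 log units; within the scatter), because a 1.6-fold lower number from compound 1 to compound 3 (0.20 log units; within the scatter) is the only measured instance of this change so far. Accordingly compound 4 is expected to give about 500 nM in this assay, most likely between 200 nM and 1300 nM.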

Compound 4, dissociation constant: 631 nM
Compound 4: the middle estimate sits 1.3-fold (0.10 log units) below what was measured, and the stated range covers the measured number.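

In this assay, cyclopropyl in place of propyl on an aromatic carbon gave a 1.3-fold lower number from compound 2 to compound 4 (0.10 log units; within the scatter). Set beside the earlier step, the change carried from the core of compound 1 to the core of compound 2 with no difference that can be told apart: the same change on two cores in this assay, a 1.6-fold lower number (0.20 log units; within the scatter) from compound 1 to compound 3 and a 1.3-fold lower number (0.10 log units; within the scatter) from compound 2 to compound 4, 1.3-fold (0.10 log units) apart, within the scatter of two such steps. Among the compounds shown here, this shows that on these two cores the exchange stays within the scatter of the measurement, so the two groups cannot be told apart here on either core, but with only two pairs in a single assay it does not show that the same would hold on any other core, and since neither step is beyond the scatter, the agreement is between two small steps rather than two clear effects.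

The compounds shown leave open how a longer chain such as pentyl, or an amine, would read in place of propyl on this aromatic carbon. They also leave open whether any such group would give steps that agree between the two cores as these do.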